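This account rests on a few compounds, and the source may have more. Where it says the series, first, only, none or still open, it means among the compounds named here.

Of the compounds shown here, three have been measured in an assay on HeLa cells for displacement of a labelled ligand from 5-hydroxytryptamine receptor 6 (Homo sapiens); a lower number here means a stronger inhibitor, a higher number a weaker inhibitor. Compound 1 `CSc1nc2ccccn2c(=N)c1S(=O)(=O)c1ccc(F)cc1` gives 22 nM. Compound 2 `Cc1ccc(Nc2nc3ccc(C)cn3c(=N)c2S(=O)(=O)c2ccccc2)nc1` gives 60 nM. Compound 3 `CSc1nc2ccc(F)cn2c(=N)c1S(=O)(=O)c1ccccc1` gives 28 nM. Among these three numbers, compound 3 stands second from the top: the gap to compound 1 lies within the usual scatter of repeated measurements, while the gap to compound 2 lies beyond it. Compound 4 `CSc1nc2ccc(C)cn2c(=N)c1S(=O)(=O)c1ccccc1` has not yet been measured. It differs from compound 3 in one place: methyl in place of fluoro on an aromatic carbon. Among the measured compounds shown here, no pair of measured compounds shows this exact exchange, so there is no measured step to lean on. In this assay an exchange of this kind on the same aromatic carbon would usually move the number only a little, so a step in either direction of no more than the usual scatter is expected, as a 1.1-fold higher number from compound 3 to compound 4 (0.03 log units; within the scatter) states. Compound 4 is therefore expected to give about 30 nM, within a range from 12 nM to 80 nM.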

Compound 4, half-maximal inhibitory concentration: 1.3 nM
Compound 4: middle estimate off by 23-fold (1.36 log units), on the high side; measured number outside the range, below it.
By their numbers in this assay, from the lowest: compound 4; then compounds 1 and 3 (each within the scatter of the next); then compound 2.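

In this assay, this aromatic carbon, two atoms from the ring nitrogen, turns out to be highly sensitive: methyl in place of fluoro, a swap of one heavy atom for one with no change in ring, hydrogen-bond donors, acceptors or charge, gives a 22-fold lower number from compound 3 to compound 4 (1.33 log units; beyond the scatter) on its own. With methyl held at that carbon, a second place also matters, since methylsulfanyl in place of (5-methylpyridin-2-yl)amino gives a 46-fold lower number from compound 2 to compound 4 (1.66 log units; beyond the scatter) in the same assay. No measurement at hand explains why either exchange has so large an effect.

On these data alone, whether chloro, ethyl or methoxy on the same carbon would match methyl remains open. So does whether methyl in place of fluoro would give a step of similar size in compounds carrying (5-methylpyridin-2-yl)amino instead of methylsulfanyl.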